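Removing the Chlorine from Compound 3

A few compounds are considered here, and "the series" means these few. Any claim that something is new, unique, unknown or untested is made for them only; others in the source may bear on it.

Of the compounds shown here, three built on the same core have been tested in an assay on isolated protein for inhibition of Aromatase (Homo sapiens), read by fluorescence; on this read-out higher numbers stand for weaker inhibition and lower numbers for stronger inhibition. Compound 1 `COC(=O)c1ccccc1S(=O)(=O)N1CCCC(Cn2ccnc2)C1` gives 53 nM. Compound 2 `O=[N+]([O-])c1cccc(Cl)c1Oc1cccc(S(=O)(=O)N2CCCC(Cn3ccnc3)C2)c1` gives 9 nM. Compound 3 `N#Cc1ccc(S(=O)(=O)N2CCCC(Cn3ccnc3)C2)c(Cl)c1` gives 79 nM. Of these numbers, that of compound 3 is the largest, but compound 1 lies close enough that the two fall within the usual scatter and no order between them can be claimed; compound 2 stands clearly lower, beyond the scatter.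

The next compound, compound 4 `N#Cc1ccc(S(=O)(=O)N2CCCC(Cn3ccnc3)C2)cc1`, has not yet been measured. It differs from compound 3 by hydrogen in place of chloro on an aromatic carbon, the site sitting ortho to a large group and meta to a cyano group. For the measured compounds named here, no measured pair in this set shows what such a change does, so the expectation rests on the change being small in size. A step of little consequence is expected, so that from compound 3 to compound 4 the shift is estimated at a 1.3-fold higher number from compound 3 to compound 4 (0.10 log units; within the scatter), not beyond the scatter. Compound 4 is therefore expected to give about 100 nM in this assay, with a likely range from 40 nM to 250 nM.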

Compound 4, half-maximal inhibitory concentration: 36 nM
Beside the measured number, compound 4's estimate is 2.8-fold (0.44 log units) above it; the whole stated range lies above it.
By their numbers in this assay, from the lowest: compound 2; then compounds 4, 1 and 3 (each within the scatter of the next, the first and the last beyond it).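

In this assay, for the compounds shown here, this is the first pair of compounds that differ in only one place, so it gives the first direct reading of this change: replacing chloro with hydrogen on the aromatic carbon, ortho to a large group and meta to a cyano group, gives a 2.2-fold lower number from compound 3 to compound 4 (0.34 log units; beyond the scatter) and so shows stronger inhibition without the chlorine. The step is modest, yet it shows that chloro is not required at this position for inhibition in this series. No measurement available here accounts for the size or direction of this step.

From the compounds shown here alone, whether a fluorine, a methyl or a methoxy group at this position would give a lower or higher number than hydrogen remains open. Also open, going by these compounds, is whether the same step would appear with an amine in place of the cyano group.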